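Chloro in place of fluoro on the urea phenyl

The compounds below may be only part of what the source reports. "The series", "measured", "known", "first", "only" and "open" are said of these compounds alone.

Of the compounds shown here, three that share one core have been measured in a functional assay on HT-29 cells (Homo sapiens) for cytotoxicity, read by MTT assay, with a stated time of 72 h; a higher number here means a weaker inhibitor, a lower number a stronger inhibitor. Compound 1 `CN(C)CCCNc1nc(-c2ccc(NC(=O)Nc3ccc(Cl)cc3)cc2)nc2c(Cl)c(Cl)sc12` gives 330 nM, compound 2 `CCN(CC)CCCNc1nc(-c2ccc(NC(=O)Nc3ccc(Cl)cc3)cc2)nc2c(Cl)c(Cl)sc12` gives 250 nM, and compound 3 `CCN(CC)CCNc1nc(-c2ccc(NC(=O)Nc3ccc(F)cc3)cc2)nc2c(Cl)c(Cl)sc12` gives 650 nM. Going by the values given here, the one step that can be read cleanly, a 1.3-fold lower number from compound 1 to compound 2 (0.12 log units; within the scatter), changes nothing outside the scatter. Compound 3 sits at the top of these numbers: its gap to compound 1 is within the scatter, and only its gap to compound 2 lies beyond it.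

Compound 4 `CCN(CC)CCNc1nc(-c2ccc(NC(=O)Nc3ccc(Cl)cc3)cc2)nc2c(Cl)c(Cl)sc12` is reached from compound 3 by chloro in place of fluoro on an aromatic carbon. Among the compounds with values here, no measured pair isolates this exchange, so the two compounds that already carry chloro, compound 1 and compound 2, are the only guide; compound 2 differs from compound 3 in two places at once, so its value shows only that the chloro-bearing partner gave the lower number there. On that thin basis a modest drop is expected, a 1.7-fold lower number from compound 3 to compound 4 (0.23 log units; within the scatter), not one that can be claimed beyond the scatter. The expected value for compound 4 in this assay is 380 nM, with a range from 160 nM to 900 nM.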

Compound 4, half-maximal inhibitory concentration: 430 nM
Compound 4: the middle estimate sits 1.1-fold (0.05 log units) below what was measured; measured number inside the range.
By their numbers in this assay, from the lowest: compounds 2, 1, 4 and 3 (each within the scatter of the next, the first and the last beyond it).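

In this assay, the exchange on the urea phenyl now has a direct reading, and chloro in place of fluoro, para to a large group, gives a 1.5-fold lower number from compound 3 to compound 4 (0.18 log units; within the scatter); at this position the two atoms cannot be told apart. Going by these compounds alone, compound 4 also gives the first look at the side chain with the chloro group in place: diethylamino in place of (diethylamino)methyl gives a 1.7-fold higher number from compound 2 to compound 4 (0.24 log units; within the scatter), and diethylamino in place of (dimethylamino)methyl gives a 1.3-fold higher number from compound 1 to compound 4 (0.11 log units; within the scatter), so neither chain change separates the compounds. The gap between compound 2 and compound 3, the only one beyond the scatter, is therefore made up of two changes that each stay within the scatter when taken alone.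

No independent measurement accounts for these small differences. Still open, going by these compounds, is whether a different group at this position, such as bromo, methyl or methoxy, would move the number beyond the scatter, and whether a morpholine or piperidine at the end of the chain would do so.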